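From Chloropropanamide to Acrylamide on a tert-Butylanilide

The source may report more compounds than this note shows. Statements on the series, on what has been measured and on what is new or still open speak of the compounds shown alone.

Of the compounds shown here, three have been measured in a functional assay on MCF7 cells (Homo sapiens) for antiproliferative activity, with a stated time of 48 h; a higher number here means a weaker inhibitor, a lower number a stronger inhibitor. Compound 1 `O=C(CCCl)Nc1ccc(I)cc1` gives 26000 nM. Compound 2 `CC(C)(C)c1ccc(NC(=O)CCCl)cc1` gives 49000 nM. Compound 3 `CC(C)(C)c1ccc(CNC(=O)CCCCl)cc1` gives 92000 nM. Compound 2 stands second highest of the three numbers, with compound 3 nearest and compound 1 furthest; both gaps lie within the scatter, so none of the three can be set apart from the others. Among the measured compounds shown here, the only step between compounds that differ in one place is a 1.9-fold higher number from compound 1 to compound 2 (0.28 log units; within the scatter), tert-butyl in place of iodo on an aromatic carbon.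

Compound 4 `C=CC(=O)Nc1ccc(C(C)(C)C)cc1` is not yet measured. Its difference from compound 2 is vinyl in place of 2-chloroethyl on a carbonyl carbon. For the measured compounds named here, no measured step changes the group on the carbonyl carbon: the single measured step alters the aromatic substituent and leaves the carbonyl side chain untouched, and compound 3 differs from compound 2 in more than one place. Going by the values given here, there is therefore no measured step that bears on this change, and the expectation can only be anchored on compound 2, whose value is 49000 nM. Compound 4 is expected to give 15000 nM, with a range from 3000 nM to 80000 nM. This estimate means an expected step of a 3.3-fold lower number from compound 2 to compound 4 (0.51 log units; beyond the scatter), with an uncertainty that spans both directions.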

Compound 4, half-maximal inhibitory concentration: 29000 nM
Beside the measured number, compound 4's estimate is 1.9-fold (0.29 log units) below it, and the stated range covers the measured number.
By their numbers in this assay, from the lowest: compounds 1, 4, 2 and 3 (each within the scatter of the next, the first and the last beyond it).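

Among the compounds shown here, compound 4 provides the first measured change to the group on the carbonyl carbon, since the earlier step altered only the aromatic substituent. In this assay, vinyl in place of 2-chloroethyl gives a 1.7-fold lower number from compound 2 to compound 4 (0.23 log units; within the scatter), so the two compounds cannot be set apart, even though the chlorine atom is gone and a double bond outside the aromatic ring has entered. Nothing available explains how either group acts in these cells, so this result stands as an observation only.

The compounds shown leave open whether an ethyl group on the carbonyl carbon, which has neither the chlorine atom nor the double bond, would also stay within the scatter of compound 2, and whether a longer chain or an aminomethyl group there would do the same. Also open, on these data alone, is whether vinyl on the carbonyl carbon would give a similar reading with iodo, as in compound 1, in place of tert-butyl on the aromatic carbon.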